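Cytotoxicity of a nitrobenzofurazan ester series: chloro to methyl

The source may hold more compounds than are shown below. What is called first, only, known or untested is meant among the compounds shown, and "the series" means these compounds.

Measured compounds:
Compound 1, `O=C(O)CCC(=O)OCCCCCCSc1ccc([N+](=O)[O-])c2nonc12`, 1890 nM in an ADME assay on L02 cells (Homo sapiens) for cytotoxicity, read by MTT assay, with a stated time of 72 h; on this read-out lower numbers stand for stronger inhibition and higher numbers for weaker inhibition.
Compound 2, `O=C(CCC(=O)OCCCCCCSc1ccc([N+](=O)[O-])c2nonc12)Nc1ccccc1Cl`, 5850 nM in this assay.

Within the data shown here, compound 2 stands highest of the two numbers seen so far in this assay; its nearest neighbour is compound 1, and the step between them, a 3.1-fold higher number from compound 1 to compound 2 (0.49 log units; beyond the scatter), is the only measured step and it replaces the hydroxy on a carbonyl carbon with the (2-chlorophenyl)amino group.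

Compound 3, `Cc1ccccc1NC(=O)CCC(=O)OCCCCCCSc1ccc([N+](=O)[O-])c2nonc12`, has not yet been measured. It differs from compound 2 by methyl in place of chloro on an aromatic carbon, read one bond further out as 2-chlorophenyl to 2-methylphenyl. Among the measured compounds shown here, no measured step touches the substituent on that aromatic ring, so the single step on hand does not bear on this change. With nothing else to go on, the change is expected to leave the number roughly where compound 2 stands, a 1.1-fold lower number from compound 2 to compound 3 (0.03 log units; within the scatter) being the estimated step, within the usual scatter.

Compound 3 is therefore estimated at 5500 nM in this assay, with a range from 2500 nM to 12000 nM.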

Compound 3, half-maximal inhibitory concentration: 9490 nM
Compound 3: the middle estimate sits 1.7-fold (0.24 log units) below what was measured, within the range that was stated.
By their numbers in this assay, from the lowest: compound 1; then compounds 2 and 3 (each within the scatter of the next).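

In this assay, among these compounds, methyl in place of chloro is the first measured change on this aromatic ring, and a 1.6-fold higher number from compound 2 to compound 3 (0.21 log units; within the scatter) shows that, at this carbon ortho to a large group, the two substituents cannot be told apart on this read-out. Among the compounds shown here, the amide result also holds with a second aryl group: a 5.0-fold higher number from compound 1 to compound 3 (0.70 log units; beyond the scatter), the same direction as a 3.1-fold higher number from compound 1 to compound 2 (0.49 log units; beyond the scatter), so both the (2-chlorophenyl)amino and the (2-methylphenyl)amino group give a higher number than the hydroxy of compound 1, with no compound here going against this. Nothing in the available data explains either step.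

The compounds shown leave open whether a group of another kind at this carbon, such as methoxy, trifluoromethyl or nitrile, or a plain phenyl ring with no substituent, would move the number beyond the scatter. They also leave open whether the step seen on replacing the hydroxy would hold with an alkyl amine in place of the aryl amines, or with a longer chain joining the ester to the shared core.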